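Dropping the hydroxymethyl from the pyrrolidine of compound 3

The compounds below may be only part of what the source reports. "The series", "measured", "known", "first", "only" and "open" are said of these compounds alone.

Measured compounds:
compound 1, `OC[C@@H]1CNC[C@H]1Nc1nc(-c2cc(F)ccc2O)nc2ccccc12`, 37 nM
compound 2, `CC(C)c1ccc(O)c(-c2nc(N[C@H]3CCNC3)c3ccccc3n2)c1`, 1700 nM
compound 3, `OC[C@H]1C[C@H](Nc2nc(-c3cc(F)ccc3O)nc3ccccc23)CN1`, 81 nM

In an assay on isolated protein for inhibition of serine/threonine-protein kinase Chk2 (Homo sapiens) (on this read-out lower numbers stand for stronger inhibition and higher numbers for weaker inhibition), compound 3 stands second highest of the three numbers. Its nearest neighbour is compound 1, and the step of a 2.2-fold higher number from compound 1 to compound 3 (0.34 log units; beyond the scatter) lies beyond the scatter. Compound 2 is far from it, but compound 2 differs from compound 3 in more than one place, so its values with compound 3 show only a wide gap and not a single change.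

Compound 4, `Oc1ccc(F)cc1-c1nc(N[C@H]2CCNC2)c2ccccc2n1`, is compound 3 with hydrogen in place of hydroxymethyl on a saturated ring carbon. Within the data shown here, no measured step describes this exact change. Among the measured compounds shown here, the only measured step, from compound 1 to compound 3, moves the hydroxymethyl rather than removing it, and it was modest. Removing the group entirely is expected to be at least as costly, so a modest rise in the number is expected in this assay, a 3.1-fold higher number from compound 3 to compound 4 (0.49 log units; beyond the scatter). The estimate for compound 4 is 250 nM, with a range from 80 nM to 800 nM.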

Compound 4, half-maximal inhibitory concentration: 60 nM
Estimate against measurement, compound 4: 4.2-fold (0.62 log units) above; the measured number lies below the stated range.
By their numbers in this assay, from the lowest: compounds 1, 4 and 3 (each within the scatter of the next, the first and the last beyond it); then compound 2.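

Removing the hydroxymethyl from the saturated ring carbon next to the ring nitrogen gives, in this assay, a 1.4-fold lower number from compound 3 to compound 4 (0.13 log units; within the scatter), so at this place the group can be lost without a change beyond the scatter. The group's other placement reads the same way, with a 1.6-fold higher number from compound 1 to compound 4 (0.21 log units; within the scatter), so the plain pyrrolidin-3-yl cannot be told apart from either hydroxymethyl form, although those two forms differ from each other beyond the scatter. The large step among these compounds lies elsewhere, at the aromatic carbon: fluoro in place of isopropyl gives a 28-fold lower number from compound 2 to compound 4 (1.45 log units; beyond the scatter).

No evidence is available to explain these numbers. As far as these compounds go, whether this ring carbon would accept a larger or charged group, such as an aminomethyl or a carboxylic acid, remains open.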